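Swapping the N-aryl for a butyl chain

A few compounds are considered here, and "the series" means these few. Any claim that something is new, unique, unknown or untested is made for them only; others in the source may bear on it.

Measured so far:
compound 1 `O=C(Nc1ccc(F)c(S(=O)(=O)N2CCOCC2)c1)c1cnn(-c2ccccc2)c1` gives 8300 nM
compound 2 `Cc1ccc(-c2nn(-c3cccc(Cl)c3)cc2C(=O)Nc2ccc(C)c(S(=O)(=O)N3CCOCC3)c2)cc1` gives 10.4 nM
compound 3 `Cc1ccc(-c2nn(-c3ccc(Cl)cc3Cl)cc2C(=O)Nc2ccc(C)c(S(=O)(=O)N3CCOCC3)c2)cc1` gives 14.1 nM

In an assay on isolated protein for antagonist activity at Bile acid receptor (Homo sapiens), read by TR-FRET, with a stated time of 20 min (a lower number here means a stronger inhibitor, a higher number a weaker inhibitor), compound 3 stands second of the three numbers shown. Its nearest neighbour is compound 2, and the step of a 1.4-fold higher number from compound 2 to compound 3 (0.13 log units; within the scatter) lies within the scatter; the furthest is compound 1, whose number is far higher, though compound 1 differs from compound 3 in several places at once, so no single change can be read from that gap.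

Compound 4 `CCCCn1cc(C(=O)Nc2ccc(C)c(S(=O)(=O)N3CCOCC3)c2)c(-c2ccc(C)cc2)n1` differs from compound 3 in one place: butyl in place of 2,4-dichlorophenyl on an aromatic nitrogen. Within the data shown here, no measured step bears directly on this change. The only step at the same position, a 1.4-fold higher number from compound 2 to compound 3 (0.13 log units; within the scatter), exchanged one aryl group for another and stayed within the scatter; replacing the ring by an open butyl chain is a different kind of change, and nothing shown tells how far the number will move. A modest rise is therefore expected, with wide uncertainty, as a 2.8-fold higher number from compound 3 to compound 4 (0.45 log units; beyond the scatter). Compound 4 is estimated at 40 nM, within a range of 8 nM to 250 nM.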

Compound 4, half-maximal inhibitory concentration: 52.5 nM
Compound 4: the middle estimate sits 1.3-fold (0.12 log units) below what was measured; measured number inside the range.
By their numbers in this assay, from the lowest: compounds 2 and 3 (each within the scatter of the next); then compound 4; then compound 1.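

In this assay, an open butyl chain on this aromatic nitrogen gives a 3.7-fold higher number from compound 3 to compound 4 (0.57 log units; beyond the scatter) and a 5.0-fold higher number from compound 2 to compound 4 (0.70 log units; beyond the scatter) when it replaces the two aryl groups. Exchanging one aryl group for another left the number within the scatter, whereas losing the aromatic ring moves it beyond the scatter, so this position does respond to the kind of group it carries. Even so, the loss is modest, which shows that an aromatic ring on this nitrogen is not essential for compound 4 to stay in reach of its aryl partners, although nothing at hand explains the shift.

Going by these compounds, whether a shorter or longer chain, or a chain ending in an amine or a carboxylic acid, would do better here remains open. So does how a cyclohexyl or benzyl group would compare with butyl and the aryl groups.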